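The source may report more compounds than this note shows. Statements on the series, on what has been measured and on what is new or still open speak of the compounds shown alone.

Measured in a functional assay on the whole organism with Scenedesmus acutus as the target; a higher number here means a weaker inhibitor, a lower number a stronger inhibitor:
- compound 1 `CC(C)OC(=O)c1cc(N2C(=O)C3=C(CCCC3)C2=O)ccc1Cl` at 1000 nM
- compound 2 `CC(C)(C)OC(=O)c1cc(N2C(=O)C3=C(CCCC3)C2=O)ccc1Cl` at 12900 nM

Compound 2 holds the higher of the two numbers, 12900 nM. Compound 3 `C#CCOc1cc(N2C(=O)C3=C(CCCC3)C2=O)ccc1Cl` has propargyloxy in place of tert-butoxycarbonyl on an aromatic carbon, ortho to a chloro group: propargyloxy in place of tert-butoxycarbonyl on an aromatic carbon. Among the compounds with values here, the only measured step is large, a 13-fold higher number from compound 1 to compound 2 (1.11 log units; beyond the scatter), and it alters the ester alone, so no measurement covers this exchange. Compound 1 at 1000 nM shows that this series reaches far lower numbers than compound 2. A large drop is therefore expected in this assay, estimated as an 18-fold lower number from compound 2 to compound 3 (1.27 log units; beyond the scatter). For compound 3 the expected value is 700 nM, with an estimated range of 100 nM to 4000 nM.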

Compound 3, half-maximal inhibitory concentration: 79.4 nM
For compound 3 the middle estimate is 8.8-fold (0.95 log units) above the measured one; the whole stated range lies above it.
By their numbers in this assay, from the lowest: compound 3; then compound 1; then compound 2.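

In this assay the place ortho to a chloro group needs no ester: propargyloxy brings a 160-fold lower number from compound 2 to compound 3 (2.21 log units; beyond the scatter) and a 13-fold lower number from compound 1 to compound 3 (1.10 log units; beyond the scatter) and so carries the series past both alkoxycarbonyl groups. Within the data shown here, with only 4 heavy atoms entering, a carbonyl is not required here for the lowest number so far. No available evidence accounts for this gain.

Still open, from the compounds shown here alone, is whether the triple bond matters, which a propoxy or allyloxy group at this place would test. The compounds shown also leave open how a shorter methoxy group would compare.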